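The compounds below may be only part of what the source reports. "The series", "measured", "known", "first", "only" and "open" are said of these compounds alone.

Measured so far, in an ADME assay on CCRF-CEM cells (Homo sapiens) for cytotoxicity, read by MTT assay, with a stated time of 5 days; on this read-out higher numbers stand for lower toxicity in this test and lower numbers for higher toxicity in this test:
- Compound 1 `COc1cc(Cc2cnc(/N=C3\C(=O)N(CN4CCCCC4C)c4ccc(Cl)cc43)nc2N)cc(OC)c1OC` reaches only the limit of the assay, > 83.8 ug/mL, not a number.
- Compound 2 `COc1cc(Cc2cnc(/N=C3\C(=O)N(CN4CCN(Cc5ccccc5)CC4)c4ccc(Cl)cc43)nc2N)cc(OC)c1OC` gives 94.7 ug/mL.
- Compound 3 `COc1cc(Cc2cnc(/N=C3\C(=O)N(CN4CCC(C)CC4)c4ccc(Cl)cc43)nc2N)cc(OC)c1OC` gives 46.3 ug/mL.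

Compound 2 holds the highest of the two numbers in this assay; its nearest neighbour is compound 3, whose number is lower by a gap beyond the usual scatter, while compound 1 contributes only a limit (the limit of > 83.8 ug/mL in this assay, at which 1 of the 3 values shown sits). The step to the unmeasured compound 4 `COc1cc(Cc2cnc(/N=C3\C(=O)N(CN4CCN(c5ccc(Cl)cc5)CC4)c4ccc(Cl)cc43)nc2N)cc(OC)c1OC` is a change at the six-membered ring with two nitrogens: 4-chlorophenyl in place of benzyl on an amine nitrogen in a ring. For the measured compounds named here, the only measured step, an at least 1.8-fold lower number from compound 1 to compound 3 (0.25 log units; that floor lies within the scatter), concerns a different place on the shared core and at its floor lies within the scatter, so no measured step touches the position changed here. On that basis, a step from compound 2 to compound 4 no larger than the scatter, in either direction, is expected: a 1.4-fold lower number from compound 2 to compound 4 (0.13 log units; within the scatter). Compound 4 is therefore estimated at 70 ug/mL in this assay, with a range from 30 ug/mL to 110 ug/mL.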

Compound 4, half-maximal cytotoxic concentration: 40.1 ug/mL
The estimate for compound 4 lay 1.7-fold (0.24 log units) above the measured number, within the range that was stated.
By their numbers in this assay, from the lowest: compounds 4 and 3 (each within the scatter of the next); then compound 2.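

For the compounds shown here, this is the first measured change at the amine nitrogen of the six-membered ring with two nitrogens: in this assay, putting 4-chlorophenyl in place of benzyl gives a 2.4-fold lower number from compound 2 to compound 4 (0.37 log units; beyond the scatter). The step is modest but beyond the scatter, so the number responds to this position even though the two groups have the same count of heavy atoms and each has one aromatic ring of carbon only. Nothing measured here bears on why the number moves.

The compounds shown do not separate the loss of the carbon that links the ring in benzyl from the arrival of chlorine, a split that plain phenyl or 4-chlorobenzyl on the same nitrogen could address. From the compounds shown here alone, how a carboxylic acid or an amine on that aromatic ring would change the number also remains open.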